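The source may report more compounds than this note shows. Statements on the series, on what has been measured and on what is new or still open speak of the compounds shown alone.

Measured so far:
- compound 1, `N=C(N)Nc1ccc(OC(=O)c2ccc(NC(=N)N)cc2)cc1`: 1.35 nM
- compound 2, `N=C(N)Nc1ccc(C(=O)Nc2cccc(NC(=N)N)c2)cc1`: 23900 nM

Both compounds were tested in an assay on isolated protein for inhibition of Trypsin (Homo sapiens), read by fluorescence, with a stated time of 15 min; a lower number here means a stronger inhibitor, a higher number a weaker inhibitor. Compound 1 gives the lowest of the two numbers, with 1.35 nM; the nearest is compound 2 with 23900 nM, a much higher number whose gap from compound 1 lies well beyond the usual scatter. From compound 1 the next step is to compound 3, `N=C(N)Nc1ccc(OC(=O)c2ccc(N)cc2)cc1`. The difference is a hydrogen atom in place of a group of 3 heavy atoms (1 carbon, 2 nitrogen; no ring), on a nitrogen on an aromatic ring. Going by the values given here, since compound 2 differs from compound 1 in several places at once, no measured pair shows what this single change does on its own. The group removed is the same kind of group that appears twice in compound 1, so losing one of them would be expected to weaken inhibition in this assay, likely by a large step rather than none. On that basis compound 3 is expected at about 200 nM, within a range of 20 nM to 3000 nM, which amounts to an expected step of a 150-fold higher number from compound 1 to compound 3 (2.17 log units; beyond the scatter).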

Compound 3, half-maximal inhibitory concentration: 2.78 nM
Compound 3: the middle estimate sits 72-fold (1.86 log units) above what was measured; measured number below the stated range.
By their numbers in this assay, from the lowest: compound 1; then compound 3; then compound 2.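

In this assay, going by these compounds alone, putting a hydrogen atom in place of the group of 3 heavy atoms, on a nitrogen on an aromatic ring, gives a 2.1-fold higher number from compound 1 to compound 3 (0.31 log units; beyond the scatter), the first change in a single place seen here. The step lies beyond the usual scatter but is modest, and compound 3 still reads 2.78 nM, so in this pair strong inhibition of the enzyme does not depend on this group being present. Nothing at hand explains why so little is lost.

On these data alone, it remains open what other groups on this same nitrogen would do, such as a methyl group or an acetyl group. As far as these compounds go, it also remains open whether the matching group elsewhere in compound 1 could be replaced by a hydrogen atom with a similarly modest step.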